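Solubility in the series: from compound 3 to compound 4

This account rests on a few compounds, and the source may have more. Where it says the series, first, only, none or still open, it means among the compounds named here.

Measured so far in a physicochemical assay for solubility, read by HPLC, in phosphate buffer, measured as thermodynamic solubility, with a stated time of 48 h, at pH 7.2; on this read-out higher numbers stand for higher solubility and lower numbers for lower solubility:
compound 1, `CCCOc1ccc(C[C@@H](Cc2ccccc2)C(=O)O)cc1CNC(=O)c1ccc(-c2cnccn2)cc1`: 32.2 ug/mL
compound 2, `CCCOc1ccc(C[C@@H](Cc2ccccc2)C(=O)O)cc1CNC(=O)c1ccc(-c2ccccc2C)cc1`: < 1 ug/mL
compound 3, `CCCOc1ccc(C[C@@H](Cc2ccccc2)C(=O)O)cc1CNC(=O)c1ccc(-c2ccc(F)cc2)cc1`: < 1 ug/mL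

The shared core carries an amide whose aryl ring bears a second ring. Compound 1 carries pyrazin-2-yl there and gives 32.2 ug/mL in this assay. For compound 3 only a limit is known in this assay, < 1 ug/mL. For compound 2 likewise only a limit is known, < 1 ug/mL. Compound 3 therefore stands at the limit of < 1 ug/mL in this assay, at which 2 of the 3 values shown sit, so the step that the two limits leave unreadable from compound 2 to compound 3 cannot be read.

Compound 4, `CCCOc1ccc(C[C@@H](Cc2ccccc2)C(=O)O)cc1CNC(=O)c1ccc(-c2ccccn2)cc1`, differs from compound 3 in one place: pyridin-2-yl in place of 4-fluorophenyl on an aromatic carbon. Within the data shown here, the steps that bear on it run the other way: an at least 32-fold lower number from compound 1 to compound 3 (1.50 log units; beyond the scatter) and an at least 32-fold lower number from compound 1 to compound 2 (1.50 log units; beyond the scatter), both large, both from a heteroaryl ring to a carbon-only ring. The change from compound 3 to compound 4 brings back a heteroaryl ring, though pyridin-2-yl rather than the pyrazin-2-yl of compound 1, so a rise in this assay beyond the scatter is expected, likely smaller than the step back to compound 1. The estimate for compound 4 is 6 ug/mL, within 1 ug/mL to 25 ug/mL, a step of an at least 6.0-fold higher number from compound 3 to compound 4 (0.77 log units; beyond the scatter) expected from compound 3, with some chance that only a limit is again reported.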

Compound 4, solubility: 17 ug/mL
Compound 4: the middle estimate sits 2.8-fold (0.45 log units) below what was measured; the measured number falls inside the stated range.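

With pyridin-2-yl at this position, on an aromatic carbon para to a large group, the series again gives a number rather than a limit in this assay, and the record shows an at least 17-fold higher number from compound 3 to compound 4 (1.23 log units; beyond the scatter), along with an at least 17-fold higher number from compound 2 to compound 4 (1.23 log units; beyond the scatter). Pyridin-2-yl and pyrazin-2-yl cannot be told apart at this position, with a 1.9-fold lower number from compound 1 to compound 4 (0.28 log units; within the scatter), so among the four compounds shown, the ring with the hetero atom count of compound 4 serves as well as the ring of compound 1 on this read-out. The carbon-only rings of compound 2 and compound 3 both remain a limit and not a number: the limit of < 1 ug/mL in this assay, at which 2 of the 4 values shown sit.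

Still open, on these data alone, is how pyridin-3-yl, pyridin-4-yl, or a saturated ring such as morpholine would read at this position, and whether a 4-fluorophenyl ring carrying an amine would leave the limit as well. The step between compound 2 and compound 3 cannot be read, and the steps from either of them stand only as lower bounds on their size.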